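The source may report more compounds than this note shows. Statements on the series, on what has been measured and on what is new or still open speak of the compounds shown alone.

Working notes on the series in a functional assay on U-87MG ATCC cells for antiproliferative activity against U-87 MG (Homo sapiens), read by MTT assay, with a stated time of 48 h, tested at 100 uM; on this read-out higher numbers stand for a weaker effect at the one concentration tested and lower numbers for a stronger effect.

Three compounds carry a number. Compound 1 `COc1ccc(-c2nc(C)c(C(=O)CSc3nc(-c4ccc(Cl)cc4)c(C#N)c(=O)[nH]3)s2)cc1` gives 2.85%. Compound 2 `COc1ccc(-c2nc(C)c(C(=O)CSc3nc(-c4ccc(OC)c(OC)c4)c(C#N)c(=O)[nH]3)s2)cc1` gives 5.39%. Compound 3 `COc1ccc(-c2nc(SCC(=O)c3sc(-c4ccc(Cl)cc4)nc3C)[nH]c(=O)c2C#N)cc1OC` gives 18.7%. Compound 2 therefore stands second highest of the three: nearest to it is compound 1, since a number 2.5 percentage points higher from compound 1 to compound 2 (within the scatter); furthest is compound 3, since a number 13.3 percentage points higher from compound 2 to compound 3 (beyond the scatter).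

The step now followed goes from compound 2 to compound 4 `COc1ccc(-c2nc(C)c(C(=O)CSc3nc(-c4ccc(Cl)c(Cl)c4)c(C#N)c(=O)[nH]3)s2)cc1`, which has not yet been measured in this assay. The change is 3,4-dichlorophenyl in place of 3,4-dimethoxyphenyl on an aromatic carbon.

Going by the values given here, of the measured steps, the one from compound 1 to compound 2 bears most directly on this, as it also exchanges a chlorinated phenyl for the 3,4-dimethoxyphenyl on the same aromatic carbon and stayed within the scatter. The step from compound 2 to compound 3 exchanges chloro for methoxy on a different ring and was modest; it bears only loosely here. On that basis no step beyond the scatter is expected in this assay, in either direction. For compound 4 this means an expected step of a number 0.9 percentage points lower from compound 2 to compound 4 (within the scatter). The estimate for compound 4 is 4.5%, with a range from 0% to 15%.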

Compound 4, a percentage reported as activity, at one concentration (the size of the read-out at that concentration, not a potency): 31.1%
For compound 4 the middle estimate is 26.6 percentage points below the measured one, and the stated range ends below it.
By their numbers in this assay, from the lowest: compounds 1 and 2 (each within the scatter of the next); then compound 3; then compound 4.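

In this assay the aromatic carbon ortho to a cyano group does not treat every aryl group alike: 3,4-dichlorophenyl in place of 3,4-dimethoxyphenyl gives a number 25.7 percentage points higher from compound 2 to compound 4 (beyond the scatter) and chloro in place of hydrogen on the phenyl ring gives a number 28.3 percentage points higher from compound 1 to compound 4 (beyond the scatter) as the effect at the one concentration tested weakens. Two groups on this phenyl ring do not by themselves go with the weaker effect, since compound 2, with its two methoxy groups, stays within the scatter of compound 1, whereas compound 4, with its two chloro groups, does not; across these three compounds the identity of the groups matters, not only their number. No measured evidence on the origin of this step is at hand.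

On these data alone, whether an unsubstituted phenyl, a hydroxyphenyl or a phenyl ring carrying an amine would sit with compounds 1 and 2 or with compound 4 remains open. Also open, as far as these compounds go, is whether the step holds at other concentrations, as each number here is the size of the read-out at a single concentration and not a potency.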